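A Bromo Swap at the Limit of the Assay

The compounds below may be only part of what the source reports. "The series", "measured", "known", "first", "only" and "open" are said of these compounds alone.

Measured in a functional assay on CEM-SS cells (Homo sapiens) for cytotoxicity; on this read-out lower numbers stand for stronger inhibition and higher numbers for weaker inhibition:
- Compound 1 `Cc1cccc(Cn2c(Cl)nc3cc(Cl)c(Cl)cc32)c1`: > 100000 nM, a limit
- Compound 2 `FC(F)(F)c1cccc(Cn2c(Cl)nc3cc(Cl)c(Cl)cc32)c1`: > 100000 nM, a limit
- Compound 3 `FC(F)(F)c1cc(Cn2c(Cl)nc3cc(Cl)c(Cl)cc32)cc(C(F)(F)F)c1`: > 100000 nM, a limit

Compound 3 stands at > 100000 nM, which is a limit and not a number. None of the three compounds has a measured number, so there is no exact starting point for the next step.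

Compound 4 `FC(F)(F)c1cc(Cn2c(Br)nc3cc(Cl)c(Cl)cc32)cc(C(F)(F)F)c1` differs from compound 3 by a single exchange on the shared core: bromo in place of chloro on an aromatic carbon. Two measured steps lead up to this point, and neither touches this chloro. They are a step that the two limits leave unreadable from compound 1 to compound 2 and a step that the two limits leave unreadable from compound 2 to compound 3. Neither has a size that can be read, so they give no measure for the new exchange. What they do show is the limit of > 100000 nM in this assay, at which 3 of the 3 values shown sit.

The expectation for compound 4 therefore rests on compound 3 at > 100000 nM, together with that shared limit. No step beyond the scatter is expected in this assay, and compound 4 will probably be reported only as a limit too. The expected change is a number no higher from compound 3 to compound 4 (the limit leaves the size open). Compound 4 is estimated at about 100000 nM, with an expected range from 40000 nM to 200000 nM.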

Compound 4, half-maximal inhibitory concentration: > 100000 nM
Compound 4 gave a limit, no number (the forecaster's own chance of this, stated with the estimate: 85%); the middle value lies on the limit itself.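

In this assay, within the data shown here, compound 3 and compound 4 both give limits and not numbers, so no size can be read for bromo in place of chloro, nor for the earlier steps. All four results sit together: the limit of > 100000 nM in this assay, at which 4 of the 4 values shown sit.

The compounds shown leave open what the actual value of each compound is, and whether this exchange changes it at all.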